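The compounds below may be only part of what the source reports. "The series", "measured", "known", "first", "only" and "open" are said of these compounds alone.

In an ADME assay on MCF-10A cells (Homo sapiens) for antiproliferative activity, read by sulforhodamine B assay, with a stated time of 48 h (on this read-out lower numbers stand for stronger inhibition of growth and higher numbers for weaker inhibition of growth), compound 1 `Clc1ccc2c(NCCCN3CCCC3)ccnc2c1` gives 45800 nM. Compound 2 `FC(F)(F)c1ccc2c(NCCCN3CCCC3)ccnc2c1` differs from it by trifluoromethyl in place of chloro on an aromatic carbon, and in this assay compound 2 gives 58700 nM. The change gave a 1.3-fold higher number from compound 1 to compound 2 (0.11 log units; within the scatter), so the two compounds sit within the usual scatter of each other.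

Compound 3 `FC(F)(F)c1ccc2c(NCCCN3CCN(c4ccnc5cc(Cl)ccc45)CC3)ccnc2c1` is built on a larger core; how its core differs from that of compound 1 is not broken down here. In this assay compound 3 gives 8840 nM, the lowest of the three numbers, and its distance to compound 1 as well as to compound 2 lies beyond the scatter.

Compound 4 `FC(F)(F)c1ccc2c(NCCCN3CCN(c4ccnc5cc(C(F)(F)F)ccc45)CC3)ccnc2c1` has not yet been measured. It differs from compound 3 by trifluoromethyl in place of chloro on an aromatic carbon. This is the same change as the one from compound 1 to compound 2: the group that leaves, the group that enters and the place are described in identical words, and the change occurs twice among the compounds shown. Going by the values given here, the single earlier instance, which gave a 1.3-fold higher number from compound 1 to compound 2 (0.11 log units; within the scatter), is the only guide, and it rests on one pair on a smaller core. On that basis the step from compound 3 to compound 4 in this assay is expected to be a 1.2-fold higher number from compound 3 to compound 4 (0.07 log units; within the scatter), that is, to stay within the scatter. For compound 4 in this assay the estimate is 10500 nM, with a range from 4500 nM to 25000 nM.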

Compound 4, concentration for 50% growth inhibition: 30000 nM
Compound 4: the middle estimate sits 2.9-fold (0.46 log units) below what was measured; the measured number lies above the stated range.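

In this assay, trifluoromethyl in place of chloro on an aromatic carbon gave a 3.4-fold higher number from compound 3 to compound 4 (0.53 log units; beyond the scatter), so on the larger core this step lies beyond the scatter. Although the step on the smaller core stayed within the scatter, the gap between the two steps does not show that they differ: the same change on two cores in this assay, a 1.3-fold higher number (0.11 log units; within the scatter) from compound 1 to compound 2 and a 3.4-fold higher number (0.53 log units; beyond the scatter) from compound 3 to compound 4, 2.6-fold (0.42 log units) apart, within the scatter of two such steps Carrying this change from one core to another therefore cannot be said to alter its size in this series, yet neither is it shown that the size holds steady, since the comparison rests on only two pairs of compounds and a real dependence on the core remains possible.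

The compounds shown leave open how other groups at this place on the aromatic ring, such as a fluorine, a methoxy or a nitrile, would compare with chloro and trifluoromethyl on either core. They also leave open whether a longer chain, or an amine other than the ones present here, would change the size of the step from chloro to trifluoromethyl.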